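Working notes: the step from compound 3 to compound 4

The source may report more compounds than this note shows. Statements on the series, on what has been measured and on what is new or still open speak of the compounds shown alone.

Measured in an ADME assay on H9c2 cells (Rattus norvegicus) for cytotoxicity; a higher number here means a weaker inhibitor, a lower number a stronger inhibitor:
- compound 1 `O=C(Nc1nc2ccc(C(F)(F)F)cc2s1)C1CC1`: > 50000 nM, a limit
- compound 2 `O=C(CCO)Nc1nc2ccc(Cl)cc2s1`: > 50000 nM, a limit
- compound 3 `FC(F)(F)c1ccc2nc(N/N=C/C3CC3)sc2c1`: 13000 nM

For the measured compounds named here, compound 3 gives the only actual number, 13000 nM. Compound 1 and compound 2 give no number and stand at the limit of > 50000 nM in this assay, at which 2 of the 3 values shown sit.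

Compound 4 `O=S(=O)(Nc1nc2ccc(C(F)(F)F)cc2s1)C1CC1` is still unmeasured. The change to it is a group of 6 heavy atoms (3 carbon, 2 oxygen, 1 sulfur; one three-membered non-aromatic ring of carbon only) in place of a group of 5 heavy atoms (4 carbon, 1 nitrogen; one three-membered non-aromatic ring of carbon only), on a nitrogen on an aromatic ring.

Going by the values given here, the one measured step that bears on this is an at least 3.8-fold lower number from compound 1 to compound 3 (0.58 log units; beyond the scatter). It is a replacement on the same nitrogen, and the new step is expected to run the opposite way at a similar size. The estimate is a 3.1-fold higher number from compound 3 to compound 4 (0.49 log units; beyond the scatter), an expected higher number in this assay.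

For compound 4 the estimated value is 40000 nM, with an expected range of 15000 nM to 100000 nM.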

Compound 4, half-maximal inhibitory concentration: 6600 nM
For compound 4 the middle estimate is 6.1-fold (0.78 log units) above the measured one; measured number outside the range, below it.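

In this assay, a carbonyl-to-sulfonyl change on this nitrogen is not neutral, as the direct swap of cyclopropylcarbonyl for cyclopropylsulfonyl gives an at least 7.5-fold lower number from compound 1 to compound 4 (0.87 log units; beyond the scatter). Compound 1 has a limit and not a number, so that step has no upper end: the limit of > 50000 nM in this assay, at which 2 of the 4 values shown sit. The hydrazone-type group of compound 3 and the cyclopropylsulfonyl group are not separated here, with a 2.0-fold lower number from compound 3 to compound 4 (0.29 log units; within the scatter).

Open, going by these compounds, is whether a sulfonyl carrying methyl or phenyl in place of cyclopropyl stays in this range. Also open, on these data alone, is whether a urea on the same nitrogen reaches the limit.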